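Alkoxy-xanthine amides: aryl amide against chlorobenzyl amide

The source may hold more compounds than are shown below. What is called first, only, known or untested is meant among the compounds shown, and "the series" means these compounds.

Compound 1 `COc1nc2c(c(=O)n(C)c(=O)n2C)n1CCCC(=O)Nc1ccc(C(C)(C)C)cc1` carries a 4-(tert-butyl)phenyl amide; in an assay on isolated protein for inhibition of high affinity 3',5'-cyclic-AMP phosphodiesterase 7A (Homo sapiens), read by cAMP accumulation, with a stated time of 10 min (on this read-out higher numbers stand for weaker inhibition and lower numbers for stronger inhibition), compound 1 gives 19800 nM. Compound 2 `COc1nc2c(c(=O)n(C)c(=O)n2C)n1CCCC(=O)NCc1ccccc1Cl` bears the change 2-chlorobenzyl in place of 4-(tert-butyl)phenyl on an amide-type nitrogen on the same core. In this assay compound 2 gives only a limit, > 200000 nM. That step is an at least 10-fold higher number from compound 1 to compound 2 (1.00 log units; beyond the scatter), read against (the limit of > 200000 nM in this assay, at which 2 of the 3 values shown sit). Compound 3 `CCOc1nc2c(c(=O)n(C)c(=O)n2C)n1CC(=O)Nc1ccc(C(C)(C)C)cc1` has a different core; the difference between the two cores is not broken down here. In this assay compound 3 gives only a limit, > 200000 nM. Compound 4 `CCOc1nc2c(c(=O)n(C)c(=O)n2C)n1CC(=O)NCc1ccccc1Cl` differs from compound 3 by 2-chlorobenzyl in place of 4-(tert-butyl)phenyl on an amide-type nitrogen, the same change at the same place. Compound 3 already sits at a limit in this assay. Given an at least 10-fold higher number from compound 1 to compound 2 (1.00 log units; beyond the scatter), compound 4 is expected to give 300000 nM, most likely again reported only as a limit, within 150000 nM to 1000000 nM. The expected step is a step that the limit leaves unreadable from compound 3 to compound 4.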

Compound 4, half-maximal inhibitory concentration: > 200000 nM
Compound 4: no number, only a limit; the forecaster's own chance of this, stated with the estimate: 90%; the middle value is on the limit's open side.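

No step can be read from compound 3 to compound 4, since both stand only as limits: the limit of > 200000 nM in this assay, at which 3 of the 4 values shown sit. On these data alone, whether 2-chlorobenzyl in place of 4-(tert-butyl)phenyl on an amide-type nitrogen shifts the read-out on the core of compound 3 as it does on the core of compound 1 remains open.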